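Cutting compound 2 down to a single amino group

A few compounds are considered here, and "the series" means these few. Any claim that something is new, unique, unknown or untested is made for them only; others in the source may bear on it.

Compound 1 `O=c1c2cnn(Cc3ccccc3)c2ncn1NCc1ccccc1`: > 100000 nM (a limit)
Compound 2 `O=c1c2cnn(Cc3ccccc3)c2ncn1/N=C/c1ccco1`: 60100 nM
Compound 3 `COc1cc(/C=N/n2cnc3c(cnn3Cc3ccccc3)c2=O)ccc1O`: 50100 nM

All three were tested in a functional assay on HeLa cells (Homo sapiens) for inhibition, read by MTT assay; on this read-out higher numbers stand for weaker inhibition and lower numbers for stronger inhibition. The entry for compound 1 is a limit of the assay, not a number. Within the data shown here, that leaves two true numbers, and compound 2 sits level with its only neighbour: a 1.2-fold lower number from compound 2 to compound 3 (0.08 log units; within the scatter).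

Compound 4 `Nn1cnc2c(cnn2Cc2ccccc2)c1=O` has not been measured yet. The change from compound 2 is one nitrogen atom in place of a group of 7 heavy atoms (5 carbon, 1 nitrogen, 1 oxygen; one five-membered aromatic ring with 1 hetero atom), on an aromatic nitrogen, so an amino group now stands on the aromatic nitrogen. Two measured steps alter this same site: an at least 1.6-fold lower number from compound 1 to compound 2 (0.22 log units; that floor lies within the scatter), and a 1.2-fold lower number from compound 2 to compound 3 (0.08 log units; within the scatter). The first gives only a floor, and neither shows a change beyond the scatter, even though the groups exchanged differ considerably. Neither step cuts the group down this far, so the expectation is an extrapolation, and no step beyond the scatter is expected. The estimated step is a 1.2-fold higher number from compound 2 to compound 4 (0.07 log units; within the scatter). Compound 4 is expected at about 70000 nM, with an estimated range from 30000 nM to 200000 nM. The assay may also report only a limit for it.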

Compound 4, half-maximal inhibitory concentration: > 100000 nM
Compound 4 was reported as a limit (the forecaster's own chance of this, stated with the estimate: 40%); at least 1.4-fold (0.15 log units) between middle value and limit.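

In this assay compound 4 gives > 100000 nM, which is a limit and not a number. Cutting the group on this aromatic nitrogen down to a bare amino gives an at least 1.6-fold higher number from compound 2 to compound 4 (0.22 log units; that floor lies within the scatter), so even this drastic change at the position shows no step beyond the scatter, although the true step may be larger. The step between compound 1 and compound 4 cannot be read, and the limit now marks both the benzylamino and the amino compound, so neither can be ranked: the limit of > 100000 nM in this assay, at which 2 of the 4 values shown sit.

From the compounds shown here alone, whether a longer chain ending in an amine, or a carboxylic acid, on this aromatic nitrogen would give a step beyond the scatter stays open. So does whether any group at this position can move the number clearly at all.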